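Methoxy Additions on the Aryl Ring: Working Notes

This account rests on a few compounds, and the source may have more. Where it says the series, first, only, none or still open, it means among the compounds named here.

Measured so far:
compound 1, `CCOC(=O)[C@@H]1CC(=O)c2sccc2[C@H]1c1ccc(OC)cc1`: 18%
compound 2, `CCOC(=O)[C@@H]1CC(=O)c2sccc2[C@H]1c1ccc(OCC)cc1`: 19.8%
compound 3, `CCOC(=O)[C@@H]1CC(=O)c2sccc2[C@H]1c1ccccc1OC`: 16%

In a physicochemical assay, with a stated time of 60 min, tested at 40 ug/mL (a lower number here means a weaker effect, a higher number a stronger effect of the compound at the concentration tested), compound 3 gives 16%. Compound 1 is nearest to it with 18%, and compound 2 is furthest with 19.8%; both gaps are within the scatter, so the three readings cannot be ordered.

Compound 4, `CCOC(=O)[C@@H]1CC(=O)c2sccc2[C@H]1c1ccc(OC)cc1OC`, is not yet measured. Relative to compound 3 the change is methoxy in place of hydrogen on an aromatic carbon.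

Within the data shown here, the one measured step, a number 1.8 percentage points higher from compound 1 to compound 2 (within the scatter), concerns a change on a saturated chain carbon, not the entry of a methoxy on an aromatic carbon, so no measured step directly bears on the change to compound 4. What the series does show is that variations on the aryl ring across compound 1, compound 2 and compound 3 all stayed within the scatter. For compound 4, therefore, a step beyond the scatter in this assay is not expected.

The expected value for compound 4 in this assay is 17%, with a range of 8% to 28%. The estimated step is a number 1 percentage points higher from compound 3 to compound 4 (within the scatter), expected to lie within the scatter.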

Compound 4, a percentage reported as activity, at one concentration (the size of the read-out at that concentration, not a potency): 12.8%
Compound 4: middle estimate off by 4.2 percentage points, on the high side, and the stated range covers the measured number.
By their numbers in this assay, from the lowest: compounds 4, 3, 1 and 2 (each within the scatter of the next).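

The methoxy entering on an aromatic carbon, meta to a methoxy group and para to a large group, can now be read directly in this assay: the reading is a number 3.2 percentage points lower from compound 3 to compound 4 (within the scatter). Among these compounds, the same entry read against the other single-methoxy compound is a number 5.2 percentage points lower from compound 1 to compound 4 (within the scatter), so a second methoxy on the aryl ring gives no step beyond the scatter from either parent, a point the earlier compounds, each with one ring substituent, could not address. No available evidence bears on the cause of these small steps.

Still open, as far as these compounds go, is whether an amine, a carboxylic acid or a longer chain such as butoxy at this place would give a step beyond the scatter. The compounds shown also leave open whether any change on the aryl ring separates clearly from the others in this read-out.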